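The compounds below may be only part of what the source reports. "The series", "measured", "known", "first", "only" and "open" are said of these compounds alone.

Of the compounds shown here, two built on a shared core have so far been tested in a functional assay on the whole organism for inhibition, with Mythimna separata as the target, with a stated time of 5 days; on this read-out lower numbers stand for an effect already at smaller amounts and higher numbers for an effect only at larger amounts of compound. Compound 1 `CCc1ccc(-c2nnc(COc3cnn(C(C)(C)C)c(=O)c3Cl)o2)cc1` gives 14.5 ug/mL in this assay. Going by the values given here, compound 2 `Cc1cccc(-c2nnc(COc3cnn(C(C)(C)C)c(=O)c3Cl)o2)c1` gives 116 ug/mL in this assay, the highest of the two numbers, and its only neighbour is compound 1 with the lower number. Among the compounds with values here, that single measured step, an 8.0-fold higher number from compound 1 to compound 2 (0.90 log units; beyond the scatter), is the only evidence of what a change of the aromatic group at this position does.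

Compound 3 `CC(C)(C)n1ncc(OCc2nnc(-c3ccc(Cl)cc3Cl)o2)c(Cl)c1=O` differs from compound 2 by 2,4-dichlorophenyl in place of 3-methylphenyl on an aromatic carbon. Within the data shown here, no measured step shows this particular exchange, and the one step seen concerns a different pair of groups, so it tells only that such swaps can move the number by a modest amount in either direction. With that limited guidance, the step is expected to be a 2.9-fold lower number from compound 2 to compound 3 (0.46 log units; beyond the scatter). Compound 3 is therefore estimated at 40 ug/mL, with a range from 10 ug/mL to 160 ug/mL.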

Compound 3, half-maximal effective concentration: 27.8 ug/mL
Estimate against measurement, compound 3: 1.4-fold (0.16 log units) above; the measured number falls inside the stated range.
By their numbers in this assay, from the lowest: compounds 1 and 3 (each within the scatter of the next); then compound 2.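

The exchange of 3-methylphenyl for 2,4-dichlorophenyl on this aromatic carbon gives a 4.2-fold lower number from compound 2 to compound 3 (0.62 log units; beyond the scatter) in this assay, so a second group now reads clearly better than 3-methylphenyl at this position. Set against 4-ethylphenyl, the same group gives a 1.9-fold higher number from compound 1 to compound 3 (0.28 log units; within the scatter), which means that these two quite different substituted phenyl groups cannot be told apart here, and compound 2 alone stands off from the other two. No measurement at hand offers an explanation for these numbers.

As far as these compounds go, the three phenyl groups differ both in what they carry and in where they carry it, so which of these matters more stays open. Also open, from the compounds shown here alone, is how a plain unsubstituted phenyl, a phenyl bearing a methoxy group or a nitrile, or a pyridine ring in its place would read.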